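The source may report more compounds than this note shows. Statements on the series, on what has been measured and on what is new or still open speak of the compounds shown alone.

Measured set:
- compound 1 `CC(Sc1nnc(-c2ccncc2)s1)C(=O)NCc1ccc(Cl)cc1`; in an ADME assay on HepG2 cells (Homo sapiens) for cytotoxicity, with a stated time of 3 days (on this read-out lower numbers stand for higher toxicity in this test and higher numbers for lower toxicity in this test), compound 1 gives "not determined" (no result reported)
- compound 2 `CC(Sc1nnc(-c2ccncc2)s1)C(=O)NCc1ccccc1`; in this assay compound 2 gives > 50000 nM, which is a limit of the test and not a number
- compound 3 `CC(Sc1nnc(-c2ccncc2)s1)C(=O)Nc1c(Cl)cccc1Cl`; in this assay compound 3 gives > 50000 nM, again a limit of the test and not a number

Among the compounds with values here, compound 1 therefore has no single number of its own on this read-out; the only numbers are the two limits above, and compound 1 cannot be placed against them. Within the data shown here, the one step between measured compounds, a step that the two limits leave unreadable from compound 2 to compound 3, is not readable in size, since both ends are limits. What the set shows is summed up in the limit of > 50000 nM in this assay, at which 2 of the 3 values shown sit.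

Compound 4 `O=C(CSc1nnc(-c2ccncc2)s1)NCc1ccc(Cl)cc1` differs from compound 1 by hydrogen in place of methyl on a saturated chain carbon bound to a carbonyl carbon and a sulfur. Among the measured compounds shown here, no measured pair follows this change, and no step touches the saturated chain carbon at all; the only step that exists changes the amide substituent and is unreadable. There is thus nothing on which a direction or size could be read for compound 4 in this assay.

With two of three values sitting at the limit, the expectation for compound 4 is that it also returns the limit, estimated at 60000 nM with a range from 20000 nM to 200000 nM.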

Compound 4, half-maximal cytotoxic concentration: > 50000 nM
Compound 4: no number, only a limit; the forecaster's own chance of this, stated with the estimate: 80%; the middle value lies beyond the limit too.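

In this assay compound 4 gives > 50000 nM, a limit of the test and not a number. Compound 1 has no number of its own, so no new step can be read between compound 1 and compound 4. Open remains whether hydrogen in place of methyl on the saturated chain carbon shifts this read-out at all.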